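Swapping a five-membered ring for oxan-3-yl on the carbonyl

A few compounds are considered here, and "the series" means these few. Any claim that something is new, unique, unknown or untested is made for them only; others in the source may bear on it.

Measured in a physicochemical assay for solubility, read by mass spectrometry, in phosphate buffer, with a stated time of 24 h, at pH 7.4 (on this read-out lower numbers stand for lower solubility and higher numbers for higher solubility), so far
compound 1 (`O=C(Nc1ccc(C(F)(F)F)cc1)NC1CCN(C(=O)C2CCCOC2)CC1`) gives 1.1 ug/mL here
compound 2 (`O=C(Nc1ccc(OC(F)(F)F)cc1)NC1CCN(C(=O)C2CCOCC2)CC1`) gives 91 ug/mL here
compound 3 (`O=C(Nc1ccc(OC(F)(F)F)cc1)NC1CCN(C(=O)C2=COCC2)CC1`) gives 11 ug/mL here

Compound 3 stands second highest of these three numbers, under compound 2 and over compound 1. Compound 4 (`O=C(Nc1ccc(OC(F)(F)F)cc1)NC1CCN(C(=O)C2CCCOC2)CC1`) departs from compound 3 in one place, on a carbonyl carbon whose other neighbours are an amide-type nitrogen in a ring. The difference is this: a group of 6 heavy atoms (5 carbon, 1 oxygen; one six-membered non-aromatic ring with 1 hetero atom) in place of a group of 5 heavy atoms (4 carbon, 1 oxygen; one five-membered non-aromatic ring with 1 hetero atom), on a carbonyl carbon and the group that enters is oxan-3-yl.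

For the measured compounds named here, one measured step bears directly on the change. It runs an 8.3-fold lower number from compound 2 to compound 3 (0.92 log units; beyond the scatter) and marks the exchange of a six-membered ring group for the same five-membered group, so the reverse exchange points upward. That earlier six-membered group is not oxan-3-yl, however. Compound 1 does carry oxan-3-yl, and compound 1 reads only 1.1 ug/mL in this assay while differing from compound 4 elsewhere as well. Going by the values given here, no measured pair isolates oxan-3-yl, so only a small upward move is expected, perhaps none beyond the scatter.

The estimated change is a 1.8-fold higher number from compound 3 to compound 4 (0.26 log units; within the scatter) on this reading. For compound 4 the expected value is 20 ug/mL with an estimated range from 4 ug/mL to 80 ug/mL in this assay once it is measured.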

Compound 4, solubility: 94 ug/mL
Compound 4: the middle estimate sits 4.7-fold (0.67 log units) below what was measured, outside the stated range (above it).
By their numbers in this assay, from the lowest: compound 1; then compound 3; then compounds 2 and 4 (each within the scatter of the next).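

In this assay, for the compounds shown here, oxan-3-yl on the carbonyl carbon gives an 8.5-fold higher number from compound 3 to compound 4 (0.93 log units; beyond the scatter), which shows that the upward move on leaving the five-membered group is not confined to oxan-4-yl, the only six-membered group the earlier step could speak for. The direct exchange of the two six-membered groups gives a 1.0-fold higher number from compound 2 to compound 4 (0.01 log units; within the scatter), so oxan-3-yl and oxan-4-yl cannot be told apart on this read-out, and at this position the compounds shown separate only the five-membered group from the two six-membered ones. With oxan-3-yl held in place, trifluoromethoxy in place of trifluoromethyl on an aromatic carbon gives an 85-fold higher number from compound 1 to compound 4 (1.93 log units; beyond the scatter), the largest step among these compounds, so the low number of compound 1 cannot be read as a mark of oxan-3-yl and instead goes with that exchange on the aromatic carbon.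

Nothing available here explains why the read-out moves with any of these exchanges. Going by these compounds, it also stays open whether an open chain such as 2-methoxyethyl, or a ring holding an amine such as piperidin-4-yl, on the same carbonyl carbon would read with the two six-membered groups or with the five-membered one.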